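The compounds below may be only part of what the source reports. "The series", "measured", "known", "first", "only" and "open" are said of these compounds alone.

Compound 1 `CN1CCN(c2ccc(Nc3nc(-c4cccc(NC(=O)c5ccc(F)cc5)c4)sc3C(N)=O)cc2)CC1` and compound 2 `CN1CCN(c2ccc(Nc3nc(-c4cccc(NC(=O)c5ccc(F)c(Cl)c5)c4)sc3C(N)=O)cc2)CC1` share a core and differ only in the amide-bound aromatic ring. In a functional assay on Raji cells (Homo sapiens) for antiproliferative activity, read by CCK-8 assay, with a stated time of 72 h, tested at 40 uM (on this read-out higher numbers stand for more inhibition at the one concentration tested (going by the name of the read-out) and lower numbers for less inhibition), compound 1 gives 95.3%, and in this assay compound 2 gives 94.4%. Within the data shown here, the single step measured, a number 0.9 percentage points lower from compound 1 to compound 2 (within the scatter), comes from chloro in place of hydrogen on an aromatic carbon. On the two numbers shown, compound 2 stands alongside compound 1, the two values lying within the usual scatter of each other, so both compounds inhibit near the top of the scale at the one concentration tested.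

Compound 3 `CN1CCN(c2ccc(Nc3nc(-c4cccc(NC(=O)[C@H]5CC[C@H](C)CC5)c4)sc3C(N)=O)cc2)CC1` arises from compound 2 by the change (4-methylcyclohexyl in place of 3-chloro-4-fluorophenyl on a carbonyl carbon). Among the measured compounds shown here, no measured step bears directly on this change: the one step from compound 1 to compound 2 swapped a substituent on the aromatic ring and lay within the scatter, whereas here the whole aromatic ring gives way to a non-aromatic one. Because compound 2 gives 94.4%, the room for an upward move is small, and a downward move is the more likely direction. The expected step is a number 12.4 percentage points lower from compound 2 to compound 3 (beyond the scatter), wide in its uncertainty. Compound 3 is therefore estimated at 82%, with a range from 45% to 98%.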

Compound 3, a percentage reported as inhibition, at one concentration (the size of the read-out at that concentration, not a potency): 22.4%
Estimate against measurement, compound 3: 59.6 percentage points above; measured number below the stated range.
By their numbers in this assay, from the lowest: compound 3; then compounds 2 and 1 (each within the scatter of the next).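

In this assay the group on the amide carbonyl carbon turns out to matter strongly: 4-methylcyclohexyl in place of 3-chloro-4-fluorophenyl gives a number 72 percentage points lower from compound 2 to compound 3 (beyond the scatter), and the same group in place of 4-fluorophenyl gives a number 72.9 percentage points lower from compound 1 to compound 3 (beyond the scatter). The earlier step, a number 0.9 percentage points lower from compound 1 to compound 2 (within the scatter), had shown only that adding chloro to the aromatic ring leaves the read-out unmoved beyond the scatter, so among these three compounds the two bearing a halogenated phenyl stay together near the top of the scale, while the one with a non-aromatic ring at this place falls far below them. Nothing given here accounts for this drop.

The compounds shown leave open whether the loss follows from giving up the aromatic ring as such or from the methyl group or the defined stereocentres of 4-methylcyclohexyl, a question that a plain cyclohexyl, the other stereoisomer or an unsubstituted phenyl on the same carbonyl carbon would bear on. Also open, as far as these compounds go, is how a pyridine ring or an open alkyl chain would read at this place, and how the compounds would compare at concentrations other than the single one tested.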